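Removing One Fluorine from a Legumain Nitrile Inhibitor

This account rests on a few compounds, and the source may have more. Where it says the series, first, only, none or still open, it means among the compounds named here.

Compound 1, `CC(C)CS(=O)(=O)N(Cc1ccc(-c2cccc(F)c2)cc1)[C@@H](C)C(=O)N[C@H](C#N)CC(N)=O`: 2270 nM
Compound 2, `C[C@H](C(=O)N[C@H](C#N)CC(N)=O)N(Cc1ccc(-c2cccc(C(F)(F)F)c2)cc1)S(C)(=O)=O`: > 10000 nM
Compound 3, `CS(=O)(=O)N(CC(=O)N[C@H](C#N)CC(N)=O)Cc1ccc(-c2cccc(F)c2F)cc1`: > 10000 nM

Of the compounds shown here, three have so far been measured in an assay on isolated protein for inhibition of legumain (Homo sapiens), with stated times of 2 min and 60 min; on this read-out lower numbers stand for stronger inhibition and higher numbers for weaker inhibition. Compound 1 gives a number, 2270 nM. For compound 2 the assay reports only a limit, > 10000 nM. Compound 3 likewise gives only a limit, > 10000 nM. Its standing among the measured compounds is therefore set by the limit of > 10000 nM in this assay, at which 2 of the 3 values shown sit: it cannot be placed by a number, only at that boundary. Going by the values given here, compound 1 and compound 3 differ in several places at once and no single step between them is given; all that can be said is that compound 1 gives a number where compound 3 gives a limit.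

Compound 4, `CS(=O)(=O)N(CC(=O)N[C@H](C#N)CC(N)=O)Cc1ccc(-c2cccc(F)c2)cc1`, has not yet been measured. It differs from compound 3 in one place: hydrogen in place of fluoro on an aromatic carbon. Among the compounds with values here, no step of this kind exists among the measured compounds, so the expectation rests on compound 3 alone. In this assay the step that the limit leaves unreadable from compound 3 to compound 4 is expected to be none beyond the scatter. Compound 4 is thus estimated to give 15000 nM, within a range of 5000 nM to 50000 nM, and most likely the assay will again report only a limit.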

Compound 4, half-maximal inhibitory concentration: > 10000 nM
Compound 4: a limit, no number; the forecaster's own chance of this, stated with the estimate: 70%; the middle value is on the limit's open side.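

Compound 3 and compound 4 each give only a limit and no number, so no step can be read between them, and compound 4 joins the compounds held at that boundary: the limit of > 10000 nM in this assay, at which 3 of the 4 values shown sit.

The compounds shown leave open whether hydrogen in place of fluoro on an aromatic carbon changes inhibition of legumain at all, and how far either compound lies past the limit.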